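Reshaping the Amide Aryl Group in a Chloro-Hydrazone Series

This account rests on a few compounds, and the source may have more. Where it says the series, first, only, none or still open, it means among the compounds named here.

In a functional assay on MDA-MB-231 cells (Homo sapiens) for inhibition, read by sulforhodamine B assay, with a stated time of 48 h (on this read-out lower numbers stand for stronger inhibition of growth and higher numbers for weaker inhibition of growth), three compounds have been measured so far:

Compound 1, `Cc1cc2c(cc1C)C(Cl)=C(/C=N\NC(=O)C1=C(Cl)c3ccccc3CCC1)CCC2`: 3100 nM
Compound 2, `O=C(N/N=C/C1=C(Cl)c2ccccc2CCC1)c1ccccc1`: 11100 nM
Compound 3, `Cc1ccc(C(=O)N/N=C/C2=C(Cl)c3ccccc3CCC2)cc1`: 710 nM

Compound 3 gives the lowest number of the three. Compound 1 stands nearest to it, and compound 2 stands furthest, both at higher numbers and both beyond the scatter.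

Compound 4, `Nc1ccccc1C(=O)N/N=C/C1=C(Cl)c2ccccc2CCC1`, has not yet been measured in this assay. It differs from compound 3 in one place: 2-aminophenyl in place of 4-methylphenyl on a carbonyl carbon. Going by the values given here, the only measured step at that carbonyl carbon is a 16-fold lower number from compound 2 to compound 3 (1.19 log units; beyond the scatter), which shows how much the aryl group on this amide can move the number. Among the compounds with values here, no measured compound carries an amino group, so nothing shows the direction for compound 4 directly; the expectation rests only on the span between compound 2 and compound 3. It is expected that compound 4 falls within that span, closer to compound 2. The expected step is a 4.2-fold higher number from compound 3 to compound 4 (0.63 log units; beyond the scatter). Compound 4 is therefore estimated at 3000 nM, within a range of 600 nM to 15000 nM.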

Compound 4, concentration for 50% growth inhibition: 5000 nM
The estimate for compound 4 lay 1.7-fold (0.22 log units) below the measured number; the range from low to high includes it.
By their numbers in this assay, from the lowest: compound 3; then compounds 1 and 4 (each within the scatter of the next); then compound 2.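

Placing 2-aminophenyl in place of 4-methylphenyl on the carbonyl carbon in this assay gives a 7.0-fold higher number from compound 3 to compound 4 (0.85 log units; beyond the scatter), so the two substituted aryl groups are not interchangeable at this position. Measured against the unsubstituted phenyl group, 2-aminophenyl still gives a 2.2-fold lower number from compound 2 to compound 4 (0.35 log units; beyond the scatter), a smaller move than a 16-fold lower number from compound 2 to compound 3 (1.19 log units; beyond the scatter). Among these three compounds, each substituent on the aromatic ring lowers the number relative to the unsubstituted phenyl group of compound 2, and none goes against this, but the size of the drop depends on the substituent.

The step from compound 3 to compound 4 changes both the substituent and where it sits, so 4-aminophenyl and 2-methylphenyl would be needed to separate the two. No available evidence accounts for these steps.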